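Working notes: from compound 3 to compound 4

The source may report more compounds than this note shows. Statements on the series, on what has been measured and on what is new or still open speak of the compounds shown alone.

Values measured in a functional assay on A549 cells (Homo sapiens) for cytotoxicity, read by MTT assay, with a stated time of 24 h (a higher number here means a weaker inhibitor, a lower number a stronger inhibitor), are as follows:
- compound 1 `C/C(=N\NC(=O)/C(C#N)=C/c1ccc(O)cc1)c1c(O)c2ccc(O)cc2oc1=O` gives 6230 nM
- compound 2 `COc1ccc(/C=C(\C#N)C(=O)N/N=C(\C)c2c(O)c3ccc(O)cc3oc2=O)cc1OC` gives 14300 nM
- compound 3 `C/C(=N\NC(=O)/C(C#N)=C/c1ccccc1[N+](=O)[O-])c1c(O)c2ccc(O)cc2oc1=O` gives 11400 nM

Compound 3 does not separate from either of the other two compounds. The measured step of a 1.8-fold higher number from compound 1 to compound 3 (0.26 log units; within the scatter) stays within the scatter, and so does a 1.3-fold lower number from compound 2 to compound 3 (0.10 log units; within the scatter) on the other side. Only a 2.3-fold higher number from compound 1 to compound 2 (0.36 log units; beyond the scatter) goes beyond the scatter, and it remains modest.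

The next compound is compound 4 `C/C(=N\NC(=O)/C(C#N)=C/c1cccc(Br)c1)c1c(O)c2ccc(O)cc2oc1=O` with 3-bromophenyl in place of 2-nitrophenyl on a double-bonded chain carbon bound to a double-bonded chain carbon. All measured steps change the group at this same place, so all of them bear on the new step. Among the measured compounds shown here, none of the measured compounds carries a bromine, so the direction of the step is poorly defined. Judged by the size of the measured steps, no step beyond the scatter is expected in this assay and the estimate means a 1.3-fold lower number from compound 3 to compound 4 (0.10 log units; within the scatter) as the expected step. For compound 4 the estimated value is 9000 nM with an expected range from 4500 nM to 18000 nM for the coming measurement.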

Compound 4, half-maximal inhibitory concentration: 22200 nM
Compound 4: the middle estimate sits 2.5-fold (0.39 log units) below what was measured; measured number outside the range, above it.
By their numbers in this assay, from the lowest: compounds 1, 3, 2 and 4 (each within the scatter of the next, the first and the last beyond it).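

In this assay, among the compounds shown here, 3-bromophenyl, the first halogen-bearing group at this place on a double-bonded chain carbon bound to a double-bonded chain carbon, does not separate compound 4 from its two nearest neighbours: the readings are a 1.9-fold higher number from compound 3 to compound 4 (0.29 log units; within the scatter) and a 1.6-fold higher number from compound 2 to compound 4 (0.19 log units; within the scatter). The separation appears only against the 4-hydroxyphenyl of compound 1, with a 3.6-fold higher number from compound 1 to compound 4 (0.55 log units; beyond the scatter), the second modest step beyond the scatter from that compound, although compound 3 goes against any claim that 4-hydroxyphenyl stands apart from every other group, given a 1.8-fold higher number from compound 1 to compound 3 (0.26 log units; within the scatter). No evidence on the cause of these differences is available.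

With a single compound for each substitution pattern, the shown set cannot separate the effect of bromine itself from that of its place on the phenyl ring, and the small spread of the steps leaves the position's tolerance only loosely defined. Still open, from the compounds shown here alone, is how this assay responds to a phenyl carrying an amine or a carboxylic acid, or to a saturated alkyl chain in place of the phenyl ring.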